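This account rests on a few compounds, and the source may have more. Where it says the series, first, only, none or still open, it means among the compounds named here.

Compound 1, with structure `CC[C@H](C)C(=O)N1CCC(NC(=O)Nc2ccc(OC(F)(F)F)c(OC(F)(F)F)c2)CC1`, is one of three compounds for which a number has been recorded in a physicochemical assay for solubility, read by mass spectrometry, in phosphate buffer, with a stated time of 24 h, at pH 7.4; a lower number here means a less soluble compound, a higher number a more soluble compound. In this assay compound 1 gives 5.5 ug/mL, the highest of the three numbers. Compound 2, with structure `O=C(Nc1ccc(C(F)(F)F)cc1)NC1CCN(C(=O)c2ccoc2)CC1`, gives 2.2 ug/mL in this assay, and compound 3, with structure `Cc1ccoc1C(=O)N1CCC(NC(=O)Nc2ccc(OC(F)(F)F)cc2)CC1`, gives 0.92 ug/mL. Both of those numbers fall beyond the usual scatter from the number of compound 1, so compound 1 stands apart at the top of this small set.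

Compound 4, with structure `CC[C@H](C)C(=O)N1CCC(NC(=O)Nc2ccc(OC(F)(F)F)c(C(F)(F)F)c2)CC1`, has not yet been measured in this assay. It differs from compound 1 in one place: trifluoromethyl in place of trifluoromethoxy on an aromatic carbon. Going by the values given here, no pair of measured compounds in the set shows this change, so nothing recorded here fixes its size or direction.

Resting only on the number of compound 1 of 5.5 ug/mL, compound 4 is expected to give a number of the same order, with the step from compound 1 to compound 4 estimated at a 1.4-fold lower number from compound 1 to compound 4 (0.14 log units; within the scatter) and likely within the scatter. The estimate for compound 4 in this assay is 4 ug/mL, in a range from 1.5 ug/mL to 10 ug/mL.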

Compound 4, solubility: 0.05 ug/mL
The estimate for compound 4 lay 80-fold (1.90 log units) above the measured number; measured number outside the range, below it.
By their numbers in this assay, from the lowest: compound 4; then compound 3; then compound 2; then compound 1.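

In this assay, trifluoromethyl in place of trifluoromethoxy on this aromatic carbon, ortho to a trifluoromethoxy group, gives a 110-fold lower number from compound 1 to compound 4 (2.04 log units; beyond the scatter), so this position is far from indifferent to the change, although the two groups differ only by the oxygen. Going by these compounds alone, this is the only step in the set between compounds that differ in one place, and it rests on this single pair. Nothing recorded here speaks to why the step is so large.

The compounds shown leave open whether the same change would give a step of this size on the aromatic carbon without a trifluoromethoxy group ortho to it, or with another amide on the shared core. They also leave open where a methoxy group, a chlorine atom or a nitrile at this position would fall relative to compound 1 and compound 4.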